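Replacing One Group on the Amide-Type Nitrogen of Compound 2

A few compounds are considered here, and "the series" means these few. Any claim that something is new, unique, unknown or untested is made for them only; others in the source may bear on it.

Three compounds have been measured in an ADME assay on microsomes from liver (Mus musculus) for metabolic stability, read by LC-MS, using NADPH, with a stated time of 10 min, tested at 0.1 uM (a lower number here means slower removal, a higher number faster removal of the compound), so far:

Compound 1 `CC1SC(c2cccc(C(=O)NCCCCc3ccccc3)c2)N(c2ccc(C3CC3)cc2)C1=O` gives 3210 mL.min-1.g-1
Compound 2 `COc1ccc(F)cc1N1C(=O)CSC1c1cccc(C(=O)NCCCCc2ccccc2)c1` gives 2250 mL.min-1.g-1
Compound 3 `O=C(NCCCCn1cccn1)c1cccc(C2SCC(=O)N2c2ccccn2)c1` gives 304 mL.min-1.g-1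

Compound 2 stands with compound 1 at the upper end of these three numbers, and the two lie within the usual scatter of each other. Compound 3 lies lower than compound 2 by a margin beyond the scatter.

The next compound is compound 4 `CC(F)(F)c1cccc(N2C(=O)CSC2c2cccc(C(=O)NCCCCc3ccccc3)c2)c1`, which departs from compound 2 in one place: a group of 10 heavy atoms (8 carbon, 2 fluorine; one six-membered aromatic ring of carbon only) in place of a group of 9 heavy atoms (7 carbon, 1 oxygen, 1 fluorine; one six-membered aromatic ring of carbon only), on an amide-type nitrogen in a ring. The 5-fluoro-2-methoxyphenyl group leaves the amide-type nitrogen in the ring, and the rest of the structure stays the same.

For the measured compounds named here, no pair of measured compounds differs in only one place, so the data hold no direct precedent for this change. The expectation rests on compound 2 at 2250 mL.min-1.g-1 and compound 1 at 3210 mL.min-1.g-1 with their shared amide side chain, as these two stay within the scatter of each other despite carrying different groups on that nitrogen. Compound 3 differs from both in more than one place and offers no separate reading of this change. The estimated step of a 1.2-fold higher number from compound 2 to compound 4 (0.06 log units; within the scatter) is expected to remain within the scatter. In this assay the estimate for compound 4 is 2600 mL.min-1.g-1 with 1300 mL.min-1.g-1 to 4800 mL.min-1.g-1 as the expected range.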

Compound 4, intrinsic clearance in microsomes: 2010 mL.min-1.g-1
Compound 4: middle estimate off by 1.3-fold (0.11 log units), on the high side, and the stated range covers the measured number.
By their numbers in this assay, from the lowest: compound 3; then compounds 4, 2 and 1 (each within the scatter of the next).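

In this assay, for the compounds shown here, the step of a 1.1-fold lower number from compound 2 to compound 4 (0.05 log units; within the scatter) is the first direct reading at this position, on an amide-type nitrogen in a ring, with the rest of the structure held the same. The 5-fluoro-2-methoxyphenyl group, with its oxygen and 1 hydrogen-bond acceptor, gives way to a group of 10 heavy atoms with 8 carbon, 2 fluorine and 0 hydrogen-bond acceptors, and the numbers stay within the scatter, so for this one pair the exchange leaves the read-out unresolved. Nothing at hand bears on why these two compounds read alike.

Going by these compounds, it remains open whether a phenyl ring carrying an amine or a carboxylic acid at this position would also stay within the scatter of compound 2, since one step between two groups built on a six-membered aromatic ring of carbon only says little about other kinds of group. Compound 3, at 304 mL.min-1.g-1, differs from compound 2 in more than one place, so the compounds shown cannot tell whether its number belongs to the group on this nitrogen or to its side chain.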